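From Allyl to Methyl on the Shared Core

The source may hold more compounds than are shown below. What is called first, only, known or untested is meant among the compounds shown, and "the series" means these compounds.

- compound 1 `C=CCn1c(=O)/c(=C\c2ccccc2Cl)[nH]c(=O)/c1=C\c1ccccc1OC`: 5100 nM
- compound 2 `C=CCn1c(=O)/c(=C\c2ccccc2C(F)(F)F)[nH]c(=O)/c1=C\c1ccccc1OC`: 4600 nM
- compound 3 `C=CCn1c(=O)/c(=C\c2ccc(F)c(Br)c2)[nH]c(=O)/c1=C\c1ccccc1OC`: "not active" (no number reported)

Going by the values given here, in a functional assay on HeLa cells (Homo sapiens) for cytotoxicity, read by CCK-8 assay, with a stated time of 72 h (on this read-out higher numbers stand for weaker inhibition and lower numbers for stronger inhibition), compound 1 has only one numerical neighbour, and the gap, a 1.1-fold lower number from compound 1 to compound 2 (0.04 log units; within the scatter), does not exceed the usual variation. Compound 3 gave no number at all, so it cannot place compound 1 any further.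

Compound 4 `COc1ccccc1/C=c1\c(=O)[nH]/c(=C/c2ccccc2Cl)c(=O)n1C` keeps the core of compound 1 but replaces allyl with methyl: hydrogen in place of vinyl on a saturated chain carbon bound to an aromatic nitrogen. Among the compounds with values here, no measured step touches this chain. Within the data shown here, the one measured step, a 1.1-fold lower number from compound 1 to compound 2 (0.04 log units; within the scatter), concerns an aromatic substituent, so it bears on the question only indirectly and gives no direction. A clear shift in this assay is therefore not predicted, although the uncertainty remains wide. The expected change is a 1.0-fold lower number from compound 1 to compound 4 (0.01 log units; within the scatter), which is an estimate with no firm direction. For compound 4 the estimated value is 5000 nM, with an expected range from 1800 nM to 14000 nM.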

Compound 4, half-maximal inhibitory concentration: 300 nM
The estimate for compound 4 lay 17-fold (1.22 log units) above the measured number; the whole stated range lies above it.
By their numbers in this assay, from the lowest: compound 4; then compounds 2 and 1 (each within the scatter of the next).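

In this assay, putting hydrogen in place of vinyl on a saturated chain carbon bound to an aromatic nitrogen, which turns allyl into methyl, gave a 17-fold lower number from compound 1 to compound 4 (1.23 log units; beyond the scatter) and so lies beyond the scatter. Going by these compounds alone, the only earlier step, on an aromatic substituent, was a 1.1-fold lower number from compound 1 to compound 2 (0.04 log units; within the scatter) and showed no change, so this chain is the first place where a single exchange moves the number clearly. Nothing available here bears on what lies behind this step.

The compounds shown leave open whether an ethyl, a longer chain or a chain ending in an amine would fall nearer compound 4 or compound 1. They also leave open whether the same exchange of allyl for methyl would carry over to the trifluoromethyl of compound 2.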